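Trifluoromethyl Replaces Isopropyl on the Aryl Ring

The compounds below may be only part of what the source reports. "The series", "measured", "known", "first", "only" and "open" are said of these compounds alone.

Measured compounds:
compound 1 `Cc1ccccc1N1CCC(C(=O)Nc2ccc3c(c2)NC(=O)CO3)CC1` gives 61 nM
compound 2 `CC(C)c1ccccc1N1CCC(C(=O)Nc2ccc3c(c2)NC(=O)CO3)CC1` gives 78 nM

Both numbers come from an assay on HEK293 cells for displacement of a labelled ligand from transient receptor potential cation channel subfamily V member 1 (Homo sapiens); on this read-out higher numbers stand for weaker inhibition and lower numbers for stronger inhibition. Compound 2 and compound 1 lie within the scatter of each other, as a 1.3-fold higher number from compound 1 to compound 2 (0.11 log units; within the scatter) shows, so no difference between them can be claimed.

Compound 3 `O=C1COc2ccc(NC(=O)C3CCN(c4ccccc4C(F)(F)F)CC3)cc2N1` has not yet been measured. It differs from compound 2 in one place: trifluoromethyl in place of isopropyl on an aromatic carbon. Among the measured compounds shown here, the only measured step that bears on this is the exchange of one group for another at the same aromatic carbon, a 1.3-fold higher number from compound 1 to compound 2 (0.11 log units; within the scatter), which stayed within the scatter. For the measured compounds named here, with only this step to go on, a change in this assay beyond the scatter is not expected, in either direction, and the step of a 1.0-fold higher number from compound 2 to compound 3 (0.01 log units; within the scatter) is the estimate made here. Compound 3 is therefore expected to give 80 nM, with a likely range from 30 nM to 220 nM.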

Compound 3, inhibition constant: 68 nM
Compound 3: middle estimate off by 1.2-fold (0.07 log units), on the high side; the range from low to high includes it.
By their numbers in this assay, from the lowest: compounds 1, 3 and 2 (each within the scatter of the next).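

In this assay, a 1.1-fold lower number from compound 2 to compound 3 (0.06 log units; within the scatter) and a 1.1-fold higher number from compound 1 to compound 3 (0.05 log units; within the scatter), so neither exchange separates the compounds, and all three stand within the scatter of one another. Among the compounds shown here, the earlier pair exchanged only one group of carbon and hydrogen for another, whereas here a group with fluorine atoms enters at the same aromatic carbon and the numbers still do not separate, so this position has now held three different groups with no difference that can be claimed. No measurement at hand accounts for this result.

As far as these compounds go, it remains open whether the same holds for a group of another kind at this carbon, such as an amine, a carboxylic acid or a longer chain. Also open, from the compounds shown here alone, is what happens with plain hydrogen there, with no group at all on that carbon.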